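Replacing the amine ring on the core of compound 1

The compounds below may be only part of what the source reports. "The series", "measured", "known", "first", "only" and "open" are said of these compounds alone.

Compound 1 `CCN1CCC(n2cc(S(=O)(=O)c3cccc(F)c3)c3cccnc32)C1` is the weaker of the two measured compounds in an assay on HeLa cells for displacement of a labelled ligand from 5-hydroxytryptamine receptor 6 (Homo sapiens) (on this read-out higher numbers stand for weaker inhibition and lower numbers for stronger inhibition), where compound 1 gives 8.3 nM. Going by the values given here, its only measured neighbour is compound 2 `CCN1CCC(n2cc(S(=O)(=O)C3=C(Cl)NC4SC=CN34)c3cccnc32)C1`, which in this assay gives 1.4 nM; that step is a 5.9-fold lower number from compound 1 to compound 2 (0.77 log units; beyond the scatter), and it alters the group on the sulfonyl sulfur rather than the group on the aromatic nitrogen. Compound 3 `O=S(=O)(c1cccc(F)c1)c1cn(C2CCCNC2)c2ncccc12` is not yet measured. It differs from compound 1 by piperidin-3-yl in place of 1-ethylpyrrolidin-3-yl on an aromatic nitrogen. Among the compounds with values here, no measured step touches this position, so the single step available does not bear on the change and its size offers no guide. Compound 3 is therefore expected to stay close to compound 1. The expected step is a 1.3-fold higher number from compound 1 to compound 3 (0.12 log units; within the scatter), which need not exceed the scatter. The estimate for compound 3 in this assay is 11 nM, ranging from 3.5 nM to 35 nM.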

Compound 3, inhibition constant: 2.4 nM
Compound 3: the middle estimate sits 4.6-fold (0.66 log units) above what was measured; the whole stated range lies above it.
By their numbers in this assay, from the lowest: compounds 2 and 3 (each within the scatter of the next); then compound 1.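

With the group on the sulfonyl sulfur held constant, piperidin-3-yl in place of 1-ethylpyrrolidin-3-yl on the aromatic nitrogen gives a 3.5-fold lower number from compound 1 to compound 3 (0.54 log units; beyond the scatter) in this assay, showing that this position, untouched by the earlier step, also responds beyond the scatter. The change has several parts: the ring goes from five-membered to six-membered, the ethyl group is lost, and the entering group has a hydrogen-bond donor that the leaving group lacks. No measured evidence here accounts for the lower number.

Which of these differences carries the step remains open; pyrrolidin-3-yl and 1-ethylpiperidin-3-yl would separate ring size from the ethyl group. Also open, from the compounds shown here alone, is whether piperidin-3-yl would lower the number in the same way alongside the group on the sulfonyl sulfur of compound 2.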